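Moving the Chlorine on the Benzyl Arm in Rats

The source may hold more compounds than are shown below. What is called first, only, known or untested is meant among the compounds shown, and "the series" means these compounds.

Measured in a functional assay on the whole organism (artery, strain albino) with Rattus norvegicus as the target, with a stated time of 15 min, at a dose of 10 mg/kg by the oral route (a lower number here means less inhibition, a higher number more inhibition at the dose given (going by the name of the read-out)), so far:
Compound 1 `COc1ccc(C2N=C(SCc3cccc(Cl)c3)NC(C)=C2C(=O)Nc2ccc(F)cc2)cc1OC` gives 2.1%.
Compound 2 `COc1ccc(C2N=C(SCc3ccc(Cl)cc3)NC(C)=C2C(=O)Nc2ccc(F)cc2)cc1OC` gives 3.1%.
Compound 3 `CC1=C(C(=O)Nc2ccc(Br)cc2)C(c2ccc(Cl)cc2Cl)N=C(SCc2cccc(Cl)c2)N1` gives 1.5%.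

Compound 4 `CC1=C(C(=O)Nc2ccc(Br)cc2)C(c2ccc(Cl)cc2Cl)N=C(SCc2ccc(Cl)cc2)N1` has not yet been measured. It differs from compound 3 by 4-chlorophenyl in place of 3-chlorophenyl on a saturated chain carbon bound to a sulfur. Exactly the same change, at the same place, separates compound 1 from compound 2: 4-chlorophenyl in place of 3-chlorophenyl on a saturated chain carbon bound to a sulfur. That step gave a number 1 percentage points higher from compound 1 to compound 2 (within the scatter), so the two chlorine positions behaved alike there. The difference between the core of compound 1 and the core of compound 3 is not broken down here; the values of all three measured compounds lie within the scatter of one another.

The step from compound 3 to compound 4 is expected to be a number 1 percentage points higher from compound 3 to compound 4 (within the scatter), because the same change produced a number 1 percentage points higher from compound 1 to compound 2 (within the scatter). Compound 4 is therefore estimated at 2.5%, likely between -5% and 10%.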

Compound 4, a percentage reported as inhibition, in the whole organism at one dose (the size of the read-out at that dose, not a potency): 4.1%
The estimate for compound 4 lay 1.6 percentage points below the measured number; low and high end bracket the measured number.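

Swapping 3-chlorobenzyl for 4-chlorobenzyl in this assay gives a number 2.6 percentage points higher from compound 3 to compound 4 (within the scatter). Set beside the earlier step, the change reads the same on both cores: the same change on two cores in this assay, a number 1 percentage points higher (within the scatter) from compound 1 to compound 2 and a number 2.6 percentage points higher (within the scatter) from compound 3 to compound 4, 1.6 percentage points apart, within the scatter of two such steps. This shows that, on these two cores, the two chlorine positions cannot be told apart, so the change carries over only in the sense that neither step stands clear of the usual spread of repeat measurements; it does not show that the change has a real effect, or that it would behave alike on any other core.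

Still open, as far as these compounds go, is whether a different group could lift the inhibition clear of that spread. An amine or a carboxylic acid in place of the chlorine, or a longer chain in place of the benzyl group, would be possible tests.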